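Arylamine in Place of Benzylamine on a Chloropyrimidine Core

This account rests on a few compounds, and the source may have more. Where it says the series, first, only, none or still open, it means among the compounds named here.

Compound 1 `Cc1ccccc1Nc1nc(Nc2cccnc2)ncc1Cl` and compound 2 `Cc1ccccc1Nc1nc(Nc2ccc(N3CCN(C)CC3)cc2)ncc1Cl` share a core and were tested in a functional assay on MDA-MB-231 cells (Homo sapiens) for inhibition, read by CCK-8 assay, with a stated time of 48 h; a higher number here means a weaker inhibitor of growth, a lower number a stronger inhibitor of growth: compound 1 gives 41200 nM, while compound 2 gives 7020 nM. Compound 3 `CN1CCN(c2ccc(Nc3ncc(Cl)c(NCc4ccc(F)cc4)n3)nc2)CC1` carries a 4-fluorobenzyl on a nitrogen on an aromatic ring, and in this assay compound 3 returns only a limit, > 100000 nM. Going by the values given here, compound 3 is the one value sitting at the limit of > 100000 nM in this assay, at which 1 of the 3 values shown sits. Compound 4 `COc1ccc(Nc2nc(Nc3ccc(N4CCN(C)CC4)cn3)ncc2Cl)cc1` awaits measurement; it differs from compound 3 by 4-methoxyphenyl in place of 4-fluorobenzyl on a nitrogen on an aromatic ring. Among the compounds with values here, no step between two measured compounds covers this change, so the size is judged from compound 2, which gives 7020 nM. A large gain in this assay is expected, the step estimated as an at least 12-fold lower number from compound 3 to compound 4 (1.09 log units; beyond the scatter). Compound 4 is accordingly estimated at 8000 nM, within a range from 2000 nM to 40000 nM.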

Compound 4, concentration for 50% growth inhibition: 8020 nM
Compound 4: the middle estimate sits 1.0-fold (0.00 log units) below what was measured; the range from low to high includes it.
By their numbers in this assay, from the lowest: compounds 2 and 4 (each within the scatter of the next); then compound 1. At a limit, above all of these: compound 3.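

In this assay, 4-methoxyphenyl in place of 4-fluorobenzyl on a nitrogen on an aromatic ring gives an at least 12-fold lower number from compound 3 to compound 4 (1.09 log units; beyond the scatter), the first step shown at this position. The change takes the series from a limit to a measured number at this place. The size of the step has only a bound, as compound 3 stands at a limit: the limit of > 100000 nM in this assay, at which 1 of the 4 values shown sits.

The compounds shown leave open whether the step follows from benzyl giving way to phenyl or from fluorine giving way to methoxy, which 4-fluorophenyl on this nitrogen would separate. As far as these compounds go, how an amine in place of the methoxy would read also remains open.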